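The source may hold more compounds than are shown below. What is called first, only, known or untested is meant among the compounds shown, and "the series" means these compounds.

Measured compounds in an ADME assay on HepG2 cells (Homo sapiens) for cytotoxicity, read by MTT assay, with a stated time of 48 h; a lower number here means a stronger inhibitor, a higher number a weaker inhibitor:

- compound 1 `Cc1ncc([N+](=O)[O-])n1CC(=O)N/N=C/c1ccc(Cl)cc1`: "not determined" (no result reported)
- compound 2 `CCc1ccc(/C=N/NC(=O)Cn2c([N+](=O)[O-])cnc2C)cc1`: > 100000 nM
- compound 3 `Cc1ncc([N+](=O)[O-])n1CC(=O)N/N=C/c1ccc(C(C)C)cc1`: "not determined" (no result reported)

Only compound 2 carries any reading, and that reading is a limit of the assay rather than a number: compound 2 gives > 100000 nM. This is the limit of > 100000 nM in this assay, at which 1 of the 3 values shown sits, so no compound here has yet shown a measurable effect on cell viability. Compound 3 therefore has no number to stand on, and its place can only be judged from the shared core, which is the same in all three.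

Compound 4 `COc1ccc(/C=N/NC(=O)Cn2c([N+](=O)[O-])cnc2C)cc1` keeps that core and differs from compound 3 in one place: methoxy in place of isopropyl on an aromatic carbon. Within the data shown here, with no measured step between any two compounds, there is no basis for expecting a difference beyond the usual scatter; the most that can be expected is that compound 4 also reaches only the limit. Compound 4 is estimated at 100000 nM, with a range from 30000 nM to 300000 nM.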

Compound 4, half-maximal inhibitory concentration: > 100000 nM
Compound 4: a limit, no number; the forecaster's own chance of this, stated with the estimate: 70%; the middle value sits exactly at the limit.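

Compound 2 and compound 4 both reach only a limit in this assay, so no step between them can be read: the limit of > 100000 nM in this assay, at which 2 of the 4 values shown sit.

The compounds shown leave open whether any change on the shared core gives a measurable effect on cell viability.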